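Swapping an amide for a sulfonamide: cytotoxicity expected unchanged

The compounds below may be only part of what the source reports. "The series", "measured", "known", "first", "only" and "open" are said of these compounds alone.

Compound 1 `CNC(=O)Nc1c(C)c(C(OC(C)(C)C)C(=O)O)c(-c2ccc(C)c(C)c2)c(C)c1-c1ccc(C)c(C)c1` carries a (methylcarbamoyl)amino group on its aromatic ring. In an ADME assay on MT4 cells (Homo sapiens) for cytotoxicity, read by MTT assay, with a stated time of 4 days (a lower number here means that less compound is tolerated, a higher number that more compound is tolerated), compound 1 gives 20000 nM, the second highest of three numbers, with both neighbours within the scatter. Compound 2 `CC(=O)Nc1c(C)c(C(OC(C)(C)C)C(=O)O)c(-c2ccc(C)c(C)c2)c(C)c1-c1ccc(C)c(C)c1` gives 19000 nM, and the step of a 1.1-fold lower number from compound 1 to compound 2 (0.02 log units; within the scatter) changed nothing beyond the scatter. Compound 3 `Cc1ccc(-c2c(C)c(-c3ccc(Cl)cc3)c(C(OC(C)(C)C)C(=O)O)c(C)c2NS(C)(=O)=O)cc1C`, which also bears a methanesulfonamido group, gives 26000 nM.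

Compound 4 `Cc1ccc(-c2c(C)c(-c3ccc(C)c(C)c3)c(C(OC(C)(C)C)C(=O)O)c(C)c2NS(C)(=O)=O)cc1C` differs from compound 1 in one place: methylsulfonyl in place of methylcarbamoyl on a nitrogen on an aromatic ring. Going by the values given here, the only measured step that touches this position, the one from compound 1 to compound 2, was within the scatter, and the sulfonamide-bearing compound 3 sits close to compound 1 as well. Nothing here points to a real shift in tolerated concentration, so compound 4 is expected to land near compound 1, with the estimated step of a 1.1-fold higher number from compound 1 to compound 4 (0.04 log units; within the scatter) staying within the scatter. The estimate for compound 4 is 22000 nM, with a range from 11000 nM to 45000 nM.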

Compound 4, half-maximal cytotoxic concentration: 15000 nM
Estimate against measurement, compound 4: 1.5-fold (0.17 log units) above, within the range that was stated.
By their numbers in this assay, from the lowest: compounds 4, 2, 1 and 3 (each within the scatter of the next).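

The methylsulfonyl group can now be compared directly with the two carbonyl-based groups on a nitrogen on an aromatic ring in this assay: replacing methylcarbamoyl gives a 1.3-fold lower number from compound 1 to compound 4 (0.12 log units; within the scatter), and replacing acetyl gives a 1.3-fold lower number from compound 2 to compound 4 (0.10 log units; within the scatter). With the methanesulfonamido group held constant, replacing 4-chlorophenyl with 3,4-dimethylphenyl on an aromatic carbon gives a 1.7-fold lower number from compound 3 to compound 4 (0.24 log units; within the scatter), so this second change also stays inside the usual variation between repeat measurements. No measurement shown explains why all of these numbers remain so close.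

Still open, on these data alone, is whether any group on this nitrogen can move the number beyond the scatter. A free amine there, or a longer chain in place of the methyl on the sulfonyl group, would test this.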